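Methyl on the carbon ring of two related cores

The compounds below may be only part of what the source reports. "The series", "measured", "known", "first", "only" and "open" are said of these compounds alone.

Measured so far in a functional assay on the whole organism (strain Sprague-Dawley) for inhibition, with Rattus norvegicus as the target; a higher number here means that more compound is needed for the effect, a lower number that less compound is needed:
compound 1 `O=c1c(-c2nn[nH]n2)c[nH]c2ccccc12` gives 1.25 mg/kg
compound 2 `Cc1ccc2[nH]cc(-c3nn[nH]n3)c(=O)c2c1` gives 1.25 mg/kg
compound 3 `c1ccc2ncc(-c3nn[nH]n3)cc2c1` gives 10 mg/kg

Compound 2 differs from compound 1 by methyl in place of hydrogen on an aromatic carbon. The step is no change at the digits printed from compound 1 to compound 2 (within the scatter), so within this pair the added methyl leaves the minimum effective dose where it was.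

Compound 3 carries a different core; the difference between the two cores is not broken down here. In this assay compound 3 stands highest of the three numbers, and its gap to compound 1 and to compound 2 lies beyond the scatter.

Compound 4 `Cc1cccc2cc(-c3nn[nH]n3)cnc12` has not yet been measured. It differs from compound 3 by methyl in place of hydrogen on an aromatic carbon. Among the compounds with values here, this is the same kind of change as the one from compound 1 to compound 2, not the same change: in compound 2 the methyl sits meta to a fused ring and para to a fused ring, in compound 4 it sits ortho to a fused ring and meta to a fused ring, and the core it sits on is the one of compound 3.

Expectation for compound 4 rests on the one measured instance of this kind of change, no change at the digits printed from compound 1 to compound 2 (within the scatter), which showed no movement. The step from compound 3 to compound 4 is therefore expected to be no change at the digits printed from compound 3 to compound 4 (within the scatter). Compound 4 is expected at 10 mg/kg, with a range from 4 mg/kg to 25 mg/kg, the width reflecting that the position and the core both differ from the measured pair.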

Compound 4, minimum effective dose: < 25 mg/kg
Compound 4 ended at the assay's limit; the forecaster's own chance of this, stated with the estimate: 10%; the middle value is on the limit's open side.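

In this assay compound 4 gives < 25 mg/kg, which is a limit of the assay and not a number. No step from compound 3 to compound 4 can be read, because the result for compound 4 is a limit: the limit of < 25 mg/kg in this assay, at which 1 of the 4 values shown sits.

The compounds shown leave open whether methyl in place of hydrogen on an aromatic carbon changes the minimum effective dose on the core of compound 3.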